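Cyanoguanidine chain variants on the shared core, stomach dose series

The compounds below may be only part of what the source reports. "The series", "measured", "known", "first", "only" and "open" are said of these compounds alone.

Measured so far:
compound 1 `CCC/N=C(/NC#N)NCCCn1nc(-c2ccccc2)ccc1=O` — 100 mg/kg
compound 2 `C/N=C(/NC#N)NCCCn1nc(-c2ccccc2)ccc1=O` — > 100 mg/kg
compound 3 `NC(=O)SCCCCCN1NC=CC=C1c1ccccc1` — 23.8 mg/kg

In a functional assay on the whole organism (stomach) with Rattus norvegicus as the target (on this read-out lower numbers stand for an effect already at smaller amounts and higher numbers for an effect only at larger amounts of compound), compound 1 gives 100 mg/kg. Compound 2 reaches only the limit of the assay, > 100 mg/kg, and no number is known for it. The step of a number no lower from compound 1 to compound 2 (the limit leaves the size open) is therefore of unreadable size, because the limit of > 100 mg/kg in this assay, at which 1 of the 3 values shown sits, marks the point where compound 2 sits. Among the compounds with values here, compound 3 gives 23.8 mg/kg in this assay; no single-point step connects it to compound 1 or compound 2, so the two values may only be set side by side.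

Compound 4 `CN(C)/C(=N/CCCn1nc(-c2ccccc2)ccc1=O)NC#N` is the unmeasured member. Its difference from compound 2 is a group of 8 heavy atoms (4 carbon, 4 nitrogen; no ring) in place of a group of 7 heavy atoms (3 carbon, 4 nitrogen; no ring), on a saturated chain carbon, three bonds along the chain from an aromatic nitrogen.

Within the data shown here, only one measured step touches the chain end that is changed here, and its size is open. Nothing on hand tells whether a change at this position moves the dose by more than the scatter in either direction. Compound 4 is expected to give about 120 mg/kg in this assay, within 40 mg/kg to 300 mg/kg, with a fair chance that only the limit is reported again. The step that the limit leaves unreadable from compound 2 to compound 4 is the expected outcome, with no direction asserted beyond the scatter.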

Compound 4, dose for half-maximal effect: 53 mg/kg
Beside the measured number, compound 4's estimate is 2.3-fold (0.35 log units) above it; the range from low to high includes it.
By their numbers in this assay, from the lowest: compound 3; then compounds 4 and 1 (each within the scatter of the next).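

In this assay, replacing the group of 7 heavy atoms with the group of 8 heavy atoms, on a saturated chain carbon, three bonds along the chain from an aromatic nitrogen, gives an at least 1.8-fold lower number from compound 2 to compound 4 (0.27 log units; that floor lies within the scatter). Compound 2 stands only at a limit of the assay: the limit of > 100 mg/kg in this assay, at which 1 of the 4 values shown sits. As far as these compounds go, the earlier step at this chain end could not be read, whereas the new one has a direction towards a lower number, although its true size stays open and its floor alone does not pass the scatter.

The compounds shown leave open how far a change at this chain end can lower the dose in this assay, and whether the lower number seen with compound 4 would hold with other groups there. A diethylamine end group, a longer alkyl chain or a carboxylic acid in the same place would test this, and would show whether any such change moves the value clearly beyond the scatter.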